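Swapping the pyridine arm for a methoxyphenyl arm

The source may hold more compounds than are shown below. What is called first, only, known or untested is meant among the compounds shown, and "the series" means these compounds.

Three compounds share a core and differ only in one aromatic arm. Compound 1 `COc1cncc(-c2c(C)nn(-c3nc(-c4ccc(Cl)c(Cl)c4)c(SC(C)C)s3)c2C(=O)O)c1` carries a 5-methoxypyridin-3-yl group and in a functional assay on BJAB cells (Homo sapiens) for antiproliferative activity, with a stated time of 4 days (a higher number here means that more compound is needed for the effect, a lower number that less compound is needed), compound 1 gives 21000 nM. Compound 2 `Cc1nn(-c2nc(-c3ccc(Cl)c(Cl)c3)c(SC(C)C)s2)c(C(=O)O)c1-c1cccc(Cl)c1C` carries 3-chloro-2-methylphenyl and gives 5100 nM. Compound 3 `CCOc1ncccc1-c1c(C)nn(-c2nc(-c3ccc(Cl)c(Cl)c3)c(SC(C)C)s2)c1C(=O)O` carries 2-ethoxypyridin-3-yl and gives 11000 nM, the second highest of the three numbers.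

Compound 4 `COc1ccccc1-c1c(C)nn(-c2nc(-c3ccc(Cl)c(Cl)c3)c(SC(C)C)s2)c1C(=O)O` changes compound 3 in one place: 2-methoxyphenyl in place of 2-ethoxypyridin-3-yl on an aromatic carbon. The ring of carbon only replaces the ring with one hetero atom, and the ethoxy becomes methoxy.

For the measured compounds named here, two measured steps bear on this. The alkoxy change alone, a 1.9-fold lower number from compound 1 to compound 3 (0.28 log units; within the scatter), hardly mattered. Replacing a pyridinyl arm by a phenyl arm, a 4.1-fold lower number from compound 1 to compound 2 (0.61 log units; beyond the scatter), lowered the number modestly, and a 2.2-fold higher number from compound 2 to compound 3 (0.33 log units; beyond the scatter) points the same way. Compound 4 keeps only part of that change, so a smaller step is expected, a 1.8-fold lower number from compound 3 to compound 4 (0.26 log units; within the scatter). Compound 4 is therefore estimated at 6000 nM, within a range of 2500 nM to 15000 nM.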

Compound 4, half-maximal effective concentration: 14700 nM
For compound 4 the middle estimate is 2.5-fold (0.39 log units) below the measured one; the measured number falls inside the stated range.
By their numbers in this assay, from the lowest: compound 2; then compounds 3, 4 and 1 (each within the scatter of the next).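

In this assay, removing the ring nitrogen and shortening ethoxy to methoxy in one change leaves the number within the scatter, a 1.3-fold higher number from compound 3 to compound 4 (0.13 log units; within the scatter), so a ring of carbon only at this position does not by itself give the lower number of the 3-chloro-2-methylphenyl arm. The exchange for the other pyridine arm also stays within the scatter, a 1.4-fold lower number from compound 1 to compound 4 (0.15 log units; within the scatter), while the exchange for 3-chloro-2-methylphenyl goes beyond it, a 2.9-fold higher number from compound 2 to compound 4 (0.46 log units; beyond the scatter), and among these four arms only 3-chloro-2-methylphenyl stands clear of the other three. No measurement available here explains these differences.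

Since the ring atom and the chain changed together, 2-ethoxyphenyl and 2-methoxypyridin-3-yl arms would be needed to read each change alone. As far as these compounds go, it also remains open whether the chlorine or the methyl of the 3-chloro-2-methylphenyl arm matters more, and how an arm bearing an amine would read.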